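The source may hold more compounds than are shown below. What is called first, only, known or untested is meant among the compounds shown, and "the series" means these compounds.

Compound 1 `CCSc1ccc(C2CC(=O)N2c2cc(OC)c(OC)c(OC)c2)cc1`: 141 nM
Compound 2 `COc1ccc(C2C(C3CC3)C(=O)N2c2cc(OC)c(OC)c(OC)c2)cc1`: 120 nM

In a functional assay on MCF7 cells (Homo sapiens) for inhibition, read by resazurin assay, with a stated time of 72 h (a higher number here means a weaker inhibitor, a lower number a stronger inhibitor), compound 2 stands level with compound 1, since the two values lie within the usual scatter of each other. Neither can be placed ahead of the other on these numbers.

The next compound to be tested is compound 3 `CCSc1ccc(C2C(C3CC3)C(=O)N2c2cc(OC)c(OC)c(OC)c2)cc1`. It differs from compound 2 in one place, with ethylsulfanyl in place of methoxy on an aromatic carbon, para to a large group (ethylsulfanyl in place of methoxy on an aromatic carbon).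

Among the measured compounds shown here, no measured pair isolates this change, so its effect in this assay has not been seen directly. For the measured compounds named here, the only guide is compound 1, which also bears ethylsulfanyl and gives 141 nM, close to the value of compound 2. On that basis, no step beyond the scatter is expected in either direction, though the evidence is thin. The expected change is a 1.1-fold higher number from compound 2 to compound 3 (0.03 log units; within the scatter). For compound 3 the estimated value is 130 nM, with an expected range from 50 nM to 350 nM.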

Compound 3, half-maximal inhibitory concentration: 606 nM
Beside the measured number, compound 3's estimate is 4.7-fold (0.67 log units) below it; the measured number lies above the stated range.
By their numbers in this assay, from the lowest: compounds 2 and 1 (each within the scatter of the next); then compound 3.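

In this assay, the para position of the aromatic ring proves sensitive once cyclopropyl is present: ethylsulfanyl in place of methoxy gives a 5.1-fold higher number from compound 2 to compound 3 (0.70 log units; beyond the scatter), while, with ethylsulfanyl kept, cyclopropyl in place of hydrogen on the saturated ring carbon gives a 4.3-fold higher number from compound 1 to compound 3 (0.63 log units; beyond the scatter). Among the compounds shown here, each change therefore carries a cost beyond the scatter in the one setting where it can be read, and compound 3, the only compound here that holds both ethylsulfanyl and cyclopropyl, has the highest number of the three, so the two groups cannot be judged from compounds that hold only one of them. No measurement shown accounts for this rise.

On these data alone, the parent holding methoxy with hydrogen in place of cyclopropyl is absent from these compounds, so it remains open whether the two changes add up simply or depend on each other. Also open, as far as these compounds go, is whether ethoxy or methylsulfanyl at this position would stand with compound 2 or with compound 3, which would separate the sulfur atom from the length of the chain.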